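The source may report more compounds than this note shows. Statements on the series, on what has been measured and on what is new or still open speak of the compounds shown alone.

Among the measured compounds shown here, compound 3 `O=S(=O)(c1ccc(F)c(F)c1)c1cnc2cc(F)ccc2c1-c1cccc(F)c1` gives 0.6 mL/min in an ADME assay on microsomes from liver (Homo sapiens) for metabolic stability, tested at 2.5 uM (a lower number here means slower removal, a higher number faster removal of the compound), the highest of the three numbers measured so far. Compound 1 `O=S(=O)(c1ccc(F)c(Cl)c1)c1cnc2cc(F)ccc2c1-c1cccc(F)c1` gives 0.25 mL/min and compound 2 `O=S(=O)(c1cccc(F)c1)c1cnc2cc(F)ccc2c1-c1cccc(F)c1` gives 0.24 mL/min; these two sit within the scatter of one another, as a 1.0-fold lower number from compound 1 to compound 2 (0.02 log units; within the scatter) shows. Against them, a 2.4-fold higher number from compound 1 to compound 3 (0.38 log units; beyond the scatter) sets compound 3 apart on one side. Compound 4 `O=S(=O)(c1ccc(F)cc1)c1cnc2cc(F)ccc2c1-c1cccc(F)c1` has not yet been run. It differs from compound 3 by hydrogen in place of fluoro on an aromatic carbon; cut one bond further out, the change reads as 3,4-difluorophenyl going to 4-fluorophenyl, the departing fluoro having stood ortho to a fluoro group and meta to a large group.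

The closest mirror is a 2.5-fold higher number from compound 2 to compound 3 (0.40 log units; beyond the scatter), where a single fluoro on this ring became two and the number rose beyond the scatter by a modest amount. Taking one fluoro off again, even though the fluoro kept in compound 4 is not the one carried by compound 2, is expected to undo roughly that much. The estimate for compound 4 is 0.3 mL/min, with a range of 0.15 mL/min to 0.6 mL/min. The expected move is a 2.0-fold lower number from compound 3 to compound 4 (0.30 log units; within the scatter), which would put compound 4 close to the level of the two lower numbers.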

Compound 4, intrinsic clearance in a liver preparation (reported as CLH), per the amount of preparation that the assay uses: 0.95 mL/min
For compound 4 the middle estimate is 3.2-fold (0.50 log units) below the measured one, and the stated range ends below it.
By their numbers in this assay, from the lowest: compounds 2 and 1 (each within the scatter of the next); then compounds 3 and 4 (each within the scatter of the next).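

In this assay, taking off the fluoro that stood ortho to a fluoro group gives a 1.6-fold higher number from compound 3 to compound 4 (0.20 log units; within the scatter) and so does not separate fluoro from hydrogen at this position on the ring. Chloro at the same position is different, since a 3.8-fold higher number from compound 1 to compound 4 (0.58 log units; beyond the scatter) lies beyond the scatter and sets chloro apart from hydrogen in the presence of the same 4-fluoro group. The place of a single fluoro also counts, as a 4.0-fold higher number from compound 2 to compound 4 (0.60 log units; beyond the scatter) separates the 3-fluorophenyl from the 4-fluorophenyl, so the number does not follow a simple count of halogens on this ring, and compound 1, which carries two halogens yet sits with compound 2 at the lower level, goes against any such count as well.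

Still open, as far as these compounds go, is whether a methyl, a methoxy or a nitrile at this position would read with chloro or with hydrogen and fluoro, and whether the gap between chloro and hydrogen survives without the 4-fluoro group. Nothing in hand gives a reason for any of these steps.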